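A Ring-Nitrogen Substituent Change Toward Compound 3

The source may hold more compounds than are shown below. What is called first, only, known or untested is meant among the compounds shown, and "the series" means these compounds.

Measured compounds:
compound 1 `COc1ccc(/C=C\C(=O)O)c(OCc2cn(-c3cccc([N+](=O)[O-])c3)nn2)c1CC=C(C)C`: "not determined" (no result reported)
compound 2 `COc1ccccc1-n1cc(COc2c(/C=C\C(=O)O)ccc(OC)c2CC=C(C)C)nn1`: 43000 nM

In a functional assay on A549 cells (Homo sapiens) for cytotoxicity, read by MTT assay, with a stated time of 24 h (on this read-out lower numbers stand for stronger inhibition and higher numbers for weaker inhibition), compound 1 gives "not determined" (no result reported), so it stands nowhere on the scale; only compound 2 offers a measured point, and in this assay compound 2 gives 43000 nM. Compound 3 `COc1ccc(/C=C\C(=O)O)c(OCc2cn(-c3cccnc3Cl)nn2)c1CC=C(C)C` differs from compound 1 in one place: 2-chloropyridin-3-yl in place of 3-nitrophenyl on an aromatic nitrogen. The change puts 2-chloropyridin-3-yl in place of 3-nitrophenyl on an aromatic nitrogen of the five-membered aromatic ring with three nitrogens, while the shared core is untouched. Going by the values given here, no measured pair tells how such a swap moves this assay, so no step beyond the usual scatter is expected in either direction, and the weak activity of compound 2 is the only guide. On that basis compound 3 is expected to give about 40000 nM in this assay, within a range from 15000 nM to 120000 nM.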

Compound 3, half-maximal inhibitory concentration: 5600 nM
Estimate against measurement, compound 3: 7.1-fold (0.85 log units) above; measured number outside the range, below it.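

In this assay, the group on the aromatic nitrogen of the five-membered aromatic ring with three nitrogens proves able to move the read-out: with the shared core untouched, 2-chloropyridin-3-yl in place of 2-methoxyphenyl gives a 7.7-fold lower number from compound 2 to compound 3 (0.89 log units; beyond the scatter). Going by these compounds alone, this is the first readable pair at this position, as the earlier compounds offered one number only; the step from compound 1 cannot be read, so 3-nitrophenyl stays unplaced against either group. Nothing at hand accounts for the size of this step.

The compounds shown do not separate the chlorine from the ring nitrogen of the new group, so how a plain pyridin-3-yl or a 2-chlorophenyl would read remains open. Also open, as far as these compounds go, is how a ring bearing an amine or a carboxylic acid would read at this position.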